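The source may report more compounds than this note shows. Statements on the series, on what has been measured and on what is new or still open speak of the compounds shown alone.

Going by the values given here, in an ADME assay on microsomes from liver (Homo sapiens) for metabolic stability (on this read-out lower numbers stand for a shorter-lived compound and higher numbers for a longer-lived compound), compound 1 (`CC(C)C(CC1C(=O)NC(=O)N1C)c1ccc(-c2ccc3cccc(F)c3c2)[nH]c1=O`) gives 0.153 h as its half-life, and that is the only exact number so far. Compound 2 (`CCC(CC)C(/C=C1\OC(=O)NC1=O)c1ccc(-c2ccc3cccc(F)c3c2)[nH]c1=O`) is reported only as a limit of > 3 h in the same measurement. Compound 1 therefore sits at the short-lived end of what has been seen, but compound 2 differs from it in more than one place and offers no clean comparison. Compound 3 (`CC(C)C(CC1NC(=O)NC1=O)c1ccc(-c2ccc3cccc(F)c3c2)[nH]c1=O`) has not yet been measured. It keeps the core of compound 1 and changes in one place (hydrogen in place of methyl on an amide-type nitrogen in a ring), with hydrogen in place of methyl on an amide-type nitrogen in a ring. Among the compounds with values here, no measured pair shows this change on its own, which leaves compound 1 at 0.153 h as the closest reference. The expected step is a modest rise a 2.6-fold higher number from compound 1 to compound 3 (0.42 log units; beyond the scatter) in this assay and only a little beyond the usual scatter. For compound 3 the estimated half-life is 0.4 h with the expected range running from 0.12 h to 1.5 h at its upper end.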

Compound 3, half-life: 1.59 h
Compound 3: the middle estimate sits 4.0-fold (0.60 log units) below what was measured; the whole stated range lies below it.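

Swapping the methyl on the amide-type nitrogen of the five-membered ring for hydrogen gives a 10-fold higher number from compound 1 to compound 3 (1.02 log units; beyond the scatter) in this assay, a large step from a very small edit. Going by these compounds alone, this is the first reading of this change on its own: the two compounds differ only in this methyl, one carbon in all, so the step can be tied to this one place on the ring, even though the pair cannot say how it arises. Nothing shown here measures why the half-life moves at this position, so the pair gives the size of the step but no cause.

Going by these compounds, how an ethyl group or a longer chain on this same ring nitrogen would read in this assay remains open, so it is unclear whether any group larger than hydrogen at this place goes with a short half-life. On these data alone, whether the same swap gives a step of similar size with a different side chain also remains open, as a single pair cannot establish a pattern.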